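Sulfonyl aryl change from compound 3 to compound 4

A few compounds are considered here, and "the series" means these few. Any claim that something is new, unique, unknown or untested is made for them only; others in the source may bear on it.

In a functional assay on LOX IMVI cells (Homo sapiens) for cytotoxicity, read by MTT assay, with a stated time of 24 h (on this read-out higher numbers stand for weaker inhibition and lower numbers for stronger inhibition), compound 1 `COc1cc(-c2nc(-c3ccccc3)[nH]c2-c2ccnc(NCCCNS(=O)(=O)c3ccc(F)cc3)n2)ccc1F` gives 3960 nM, compound 2 `COc1cc(-c2nc(-c3ccccc3)[nH]c2-c2ccnc(NCCCNS(=O)(=O)c3cccc(F)c3)n2)ccc1F` gives 900 nM and compound 3 `COc1cc(-c2nc(-c3ccccc3)[nH]c2-c2ccnc(NCCCNS(=O)(=O)c3ccc(C)cc3)n2)ccc1F` gives 2590 nM. The measured steps are a 1.5-fold lower number from compound 1 to compound 3 (0.18 log units; within the scatter) and a 2.9-fold higher number from compound 2 to compound 3 (0.46 log units; beyond the scatter), so this last value stays near the top of the set. The next structure is compound 4 `COc1cc(-c2nc(-c3ccccc3)[nH]c2-c2ccnc(NCCCNS(=O)(=O)c3cccc4ccccc34)n2)ccc1F`, with naphthalen-1-yl in place of 4-methylphenyl on a sulfonyl sulfur. Only aryl changes on the sulfonyl sulfur bear on this, and the largest is a 4.4-fold lower number from compound 1 to compound 2 (0.64 log units; beyond the scatter), which is modest. None of them brings in naphthalen-1-yl, so the expectation is weakly founded. In this assay the expected change is small, and the estimated step is a 1.3-fold lower number from compound 3 to compound 4 (0.11 log units; within the scatter). Compound 4 is estimated at 2000 nM, with an expected range of 700 nM to 5500 nM.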

Compound 4, half-maximal inhibitory concentration: 14900 nM
Compound 4: middle estimate off by 7.5-fold (0.87 log units), on the low side, and the stated range ends below it.
By their numbers in this assay, from the lowest: compound 2; then compounds 3 and 1 (each within the scatter of the next); then compound 4.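

In this assay naphthalen-1-yl on a sulfonyl sulfur brings a 5.8-fold higher number from compound 3 to compound 4 (0.76 log units; beyond the scatter) and a 3.8-fold higher number from compound 1 to compound 4 (0.58 log units; beyond the scatter) and also a 17-fold higher number from compound 2 to compound 4 (1.22 log units; beyond the scatter) so compound 4 is the weakest of the four. Going by these compounds alone, the earlier compounds carried one six-membered aromatic ring here and stayed closer together, so this position does not accept every aryl group alike, and the one compound with 2 such rings sits highest. Nothing at hand explains the shift.

Going by these compounds, whether the second ring or its point of attachment matters remains open. Naphthalen-2-yl and cyclohexyl on the sulfonyl sulfur would separate these readings.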